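A few compounds are considered here, and "the series" means these few. Any claim that something is new, unique, unknown or untested is made for them only; others in the source may bear on it.

Compound 1 `C=CC1=C(C(=O)NCCC)C(c2ccc(F)cc2)OC1` is the starting point of this step. In a functional assay on HeLa cells (Homo sapiens) for cytotoxicity, read by MTT assay, with a stated time of 24 h (on this read-out lower numbers stand for stronger inhibition and higher numbers for weaker inhibition), compound 1 gives only a limit, > 100000 nM, and not a number. Two further compounds set the scene. Compound 2 `C=CC1=C(C(=O)NCc2ccccc2)C(c2ccc(OC)c(OC)c2)OC1` likewise gives a limit, > 100000 nM, in this assay. Compound 3 `C=CC1=C(C(=O)NCC(C)C)C(c2ccc(Cl)c(Cl)c2)OC1` gives 60100 nM in this assay, a number rather than a limit. Compound 1 therefore stands at the limit of > 100000 nM in this assay, at which 2 of the 3 values shown sit, and nothing measured here shows a strong inhibitor. The new compound, compound 4 `C=CC1=C(C(=O)Nc2cccc(C)c2)C(c2ccc(F)cc2)OC1`, differs from compound 1 in a single place: 3-methylphenyl in place of propyl on an amide-type nitrogen. Going by the values given here, no measured pair in this set carries such a change, so its effect cannot be read off from any neighbour, and the values of compounds 2 and 3 only show weak inhibition across the measured compounds. Among the compounds with values here, with no measured step to lean on, the expected step is a number no higher from compound 1 to compound 4 (the limit leaves the size open), nothing beyond the scatter. Compound 4 is accordingly expected to give about 100000 nM, between 40000 nM and 300000 nM, in this assay, most likely reported once more only as a limit.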

Compound 4, half-maximal inhibitory concentration: "not active" (no number reported)
The entry for compound 4 holds no number; the estimate stays without a comparison.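

Compound 4 is reported as "not active" without a number, and compound 1 gives only a limit, so no step can be read between compound 1 and compound 4. The compounds shown leave open whether 3-methylphenyl in place of propyl on the amide-type nitrogen changes anything in this assay at all.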